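The source may report more compounds than this note shows. Statements on the series, on what has been measured and on what is new or still open speak of the compounds shown alone.

Measured so far:
- Compound 1 `COc1cc(/C=C2\CN(C)C/C(=C\c3ccc(Cl)cc3Cl)C2=O)cc(OC)c1`: 18800 nM
- Compound 2 `COc1cc(/C=C2\CN(C)C/C(=C\c3cc(OC)c(OC)c(OC)c3)C2=O)cc(OC)c1`: 14600 nM

Both values come from an ADME assay on L02 cells (Homo sapiens) for cytotoxicity, read by MTT assay, with a stated time of 24 h; on this read-out higher numbers stand for weaker inhibition and lower numbers for stronger inhibition. Compound 2 lies within the usual scatter of compound 1, so the two cannot be told apart.

Compound 3 `COc1cc(/C=C2\CN(C)C/C(=C\c3ccc(Cl)c(Cl)c3)C2=O)cc(OC)c1OC` has not been measured. It differs from compound 2 in one place: 3,4-dichlorophenyl in place of 3,5-dimethoxyphenyl on a double-bonded chain carbon bound to a double-bonded ring carbon, with 3,4-dichlorophenyl in place of 3,5-dimethoxyphenyl on a double-bonded chain carbon bound to a double-bonded ring carbon. Among the measured compounds shown here, no measured pair shows this change alone, so no step beyond the scatter is expected in this assay. The expected step, a 1.0-fold higher number from compound 2 to compound 3 (0.01 log units; within the scatter), is small. For compound 3 the estimated value is 15000 nM, with an expected range of 6000 nM to 35000 nM.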

Compound 3, half-maximal inhibitory concentration: 18400 nM
Beside the measured number, compound 3's estimate is 1.2-fold (0.09 log units) below it, within the range that was stated.
By their numbers in this assay, from the lowest: compounds 2, 3 and 1 (each within the scatter of the next).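

In this assay, putting 3,4-dichlorophenyl in place of 3,5-dimethoxyphenyl on a double-bonded chain carbon bound to a double-bonded ring carbon gives a 1.3-fold higher number from compound 2 to compound 3 (0.10 log units; within the scatter). Among the compounds shown here, this is the first comparison that changes only one place, and the two groups cannot be told apart here, although one carries chlorine and the other carries oxygen. That holds for this single pair only. Going by these compounds, whether an amine or a carboxylic acid in this place would shift the number beyond the scatter remains open. No measurement on hand explains why these two groups read alike.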